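Aryl variation on the amide carbonyl of the shared core

The source may hold more compounds than are shown below. What is called first, only, known or untested is meant among the compounds shown, and "the series" means these compounds.

Measured so far in a functional assay on LOX IMVI cells (Homo sapiens) for antiproliferative activity, read by sulforhodamine B assay, with a stated time of 48 h; on this read-out lower numbers stand for stronger inhibition and higher numbers for weaker inhibition:
compound 1 `COc1cc(-c2nn(-c3ccc(NC(=O)Nc4ccc(Cl)c(Cl)c4)cc3)cc2-c2ccncc2)ccc1Cl`: 1980 nM
compound 2 `COc1cc(-c2nn(-c3ccc(NC(=O)c4cc(Cl)cc(Cl)c4)cc3)cc2-c2ccncc2)ccc1Cl`: 3090 nM

Within the data shown here, compound 2 carries the highest of the two numbers; the nearest is compound 1, and the only measured step, a 1.6-fold higher number from compound 1 to compound 2 (0.19 log units; within the scatter), lies within the scatter. The two compounds therefore cannot be ordered against each other on this read-out.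

Compound 3 `COc1cc(-c2nn(-c3ccc(NC(=O)c4ccc(Cl)c(C(F)(F)F)c4)cc3)cc2-c2ccncc2)ccc1Cl` differs from compound 2 in one place: 4-chloro-3-(trifluoromethyl)phenyl in place of 3,5-dichlorophenyl on a carbonyl carbon. Among the measured compounds shown here, no measured pair changes the substituents of the aryl group on the carbonyl carbon while keeping the amide linkage, so the one step on record bears on this change only loosely. That step exchanged the carbonyl environment itself and still stayed within the scatter, which gives no ground to expect a move beyond the scatter here in either direction in this assay.

Compound 3 is expected to give 3000 nM, with the range 1200 nM to 7500 nM, the expected step being a 1.0-fold lower number from compound 2 to compound 3 (0.01 log units; within the scatter).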

Compound 3, half-maximal inhibitory concentration: 1560 nM
For compound 3 the middle estimate is 1.9-fold (0.28 log units) above the measured one; measured number inside the range.
By their numbers in this assay, from the lowest: compounds 3, 1 and 2 (each within the scatter of the next).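

Among these compounds, the first pair that keeps the amide linkage and changes only the aryl group on the carbonyl carbon gives, in this assay, a 2.0-fold lower number from compound 2 to compound 3 (0.30 log units; within the scatter) and so does not separate 4-chloro-3-(trifluoromethyl)phenyl from 3,5-dichlorophenyl, even though the entering group has the higher heavy-atom count and carries fluorine. The exchange of (3,4-dichlorophenyl)amino for 4-chloro-3-(trifluoromethyl)phenyl on the carbonyl carbon gives a 1.3-fold lower number from compound 1 to compound 3 (0.10 log units; within the scatter) and also stays within the scatter, so compounds 1, 2 and 3 remain unordered and no exchange at this position has yet left the scatter. Nothing on record bears on why these three numbers lie so close together.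

Still open, from the compounds shown here alone, is whether any group on this carbonyl carbon moves the number beyond the scatter, for example an aryl group carrying an amine or a carboxylic acid, a plain unsubstituted phenyl, or a longer alkyl chain in place of the aryl ring. The compounds shown also leave open whether the chlorine on the 4-chloro-3-(trifluoromethyl)phenyl group can be exchanged for a methoxy group or a nitrile with the number staying within the scatter.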